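The source may report more compounds than this note shows. Statements on the series, on what has been measured and on what is new or still open speak of the compounds shown alone.

In an ADME assay on microsomes from liver (Rattus norvegicus) for metabolic stability, with a stated time of 10 min, tested at 1 uM (a lower number here means that less of the compound is left, a higher number that more of the compound is left), compound 2 (`Cc1cc(C(F)(F)F)ccc1-c1cc2cnn([C@@H](CC(C)C)c3ccc(C(=O)NCCC(=O)O)cc3)c2cc1C`) gives 116%. Compound 3 (`Cc1cc(C(F)(F)F)ccc1-c1ccc2nn([C@@H](CC(C)C)c3ccc(C(=O)NCCC(=O)O)cc3)cc2c1C`) gives 107%, within the scatter of compound 2, while compound 1 (`COc1c(-c2ccc(C(F)(F)F)cc2Cl)ccc2nn([C@@H](CC(C)C)c3ccc(C(=O)NCCC(=O)O)cc3)cc12`), at 84%, lies lower than compound 2 by more than the scatter. Compound 4 (`Cc1cc2c(cnn2[C@@H](CC(C)C)c2ccc(C(=O)NCCC(=O)O)cc2)cc1-c1ccc(C(F)(F)F)cc1Cl`) has not yet been measured. It differs from compound 2 by chloro in place of methyl on an aromatic carbon, giving 2-chloro-4-(trifluoromethyl)phenyl. Going by the values given here, no measured pair isolates this change. Among the compounds with values here, the only guide is compound 1, which carries the same 2-chloro-4-(trifluoromethyl)phenyl group and reads 84%, so a fall is expected. The expected step is a number 14 percentage points lower from compound 2 to compound 4 (beyond the scatter), a modest one downward. Compound 4 is estimated at 102%, with an expected range of 85% to 118%.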

Compound 4, percent of the compound remaining: 67%
The estimate for compound 4 lay 35 percentage points above the measured number, outside the stated range (below it).
By their numbers in this assay, from the lowest: compound 4; then compound 1; then compounds 3 and 2 (each within the scatter of the next).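

In this assay, going by these compounds alone, chloro in place of methyl, on an aromatic carbon ortho to a large group, gives a step of a number 49 percentage points lower from compound 2 to compound 4 (beyond the scatter), the first reading of this change in isolation. It shows that this position is sensitive to the group it carries: one heavy atom replaces one heavy atom, with no hydrogen-bond donor or acceptor gained or lost. Nothing available accounts for the size of this step. On these data alone, whether fluoro, methoxy or a nitrile at this place would track chloro or methyl remains open, as does whether the same exchange would give a similar step on the core of compound 3.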